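The source may hold more compounds than are shown below. What is called first, only, known or untested is meant among the compounds shown, and "the series" means these compounds.

Compound 1 `C[C@H](Nc1nc(N)nc(N)c1C#N)c1cc2ccc(F)cn2c(=O)c1-c1ccccc1` is the reference point for everything that follows: in an ADME assay on microsomes from liver (Mus musculus), read by LC-MS, using NADPH, with a stated time of 30 min, tested at 1 uM (a lower number here means that less of the compound is left, a higher number that more of the compound is left), compound 1 gives 42%. Compound 2 `C[C@H](Nc1ccnc(N)n1)c1cc2ccc(F)cn2c(=O)c1-c1ccccc1` was also entered into this assay, but there the entry for compound 2 reads "not determined" (no result reported), so it contributes nothing to the comparison. Compound 3 `Cc1c([C@H](C)Nc2nc(N)nc(N)c2C#N)c(-c2ccccc2)c(=O)n2cc(F)ccc12` has not yet been measured. Compared with compound 1, compound 3 carries methyl in place of hydrogen on an aromatic carbon, that is, methyl in place of hydrogen on an aromatic carbon of the shared core. Among the compounds with values here, no pair of measured compounds that differ in a single place is available, so the size of this step cannot be read from any measured precedent. Without such a precedent, the expectation is a step of modest size at most, more likely downward than upward, and quite possibly within the usual scatter of repeated runs. Compound 3 is therefore expected to give 38% in this assay, within an estimated range from 20% to 60%. That expectation amounts to a step of a number 4 percentage points lower from compound 1 to compound 3 (within the scatter).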

Compound 3, percent of the compound remaining: 85%
Beside the measured number, compound 3's estimate is 47 percentage points below it; measured number outside the range, above it.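

In this assay, methyl in place of hydrogen on an aromatic carbon of the shared core gives a number 43 percentage points higher from compound 1 to compound 3 (beyond the scatter) and this step lies beyond the scatter. The change adds only 1 heavy atom, with no ring, no hydrogen-bond donors or acceptors and no net charge, so this position, ortho to a large group and two atoms from the ring nitrogen, is one where a very small change goes with a large difference in the percentage of compound remaining. Within the data shown here, this is the only step that can be read so far and it rests on a single pair, while no measurement offered here says why the methyl has this effect.

The compounds shown leave open whether the difference belongs to methyl in particular or would also appear with another group on this carbon, such as a fluorine, a chlorine, an ethyl or a methoxy group. They also leave open whether the same methyl would give a step of similar size if the nitrile of compound 1 were replaced by another group, such as an amine or a carboxylic acid.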